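Swapping the Aryl Amide Substituent in an Adenosine Ligand

A few compounds are considered here, and "the series" means these few. Any claim that something is new, unique, unknown or untested is made for them only; others in the source may bear on it.

Compound 1 `CCOc1ccccc1C(=O)Nc1nc(-c2ccccc2)nc2c1nnn2Cc1ccccc1` gives 1850 nM in an assay (strain Wistar) for displacement of a labelled ligand from adenosine receptor A1 (Rattus norvegicus), read by scintillation counting (on this read-out lower numbers stand for stronger inhibition and higher numbers for weaker inhibition), the higher of the two numbers recorded. Compound 2 `O=C(Nc1nc(-c2ccccc2)nc2c1nnn2Cc1ccccc1)C1CCCCC1` gives 12 nM, and the step of a 150-fold lower number from compound 1 to compound 2 (2.19 log units; beyond the scatter) is the only one measured. Compound 3 `Cc1ccc(C(=O)Nc2nc(-c3ccccc3)nc3c2nnn3Cc2ccccc2)cc1` differs from compound 1 by 4-methylphenyl in place of 2-ethoxyphenyl on a carbonyl carbon. This exchanges one aromatic group for another, whereas the measured step replaced the aromatic group with cyclohexyl, so that step bears on compound 3 only loosely. A modest move toward lower numbers is expected, a 3.1-fold lower number from compound 1 to compound 3 (0.49 log units; beyond the scatter). Compound 3 is therefore estimated at 600 nM, within 100 nM to 3500 nM.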

Compound 3, inhibition constant: 709 nM
Compound 3: the middle estimate sits 1.2-fold (0.07 log units) below what was measured, and the stated range covers the measured number.
By their numbers in this assay, from the lowest: compound 2; then compound 3; then compound 1.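

Exchanging 2-ethoxyphenyl for 4-methylphenyl on the carbonyl carbon gives a 2.6-fold lower number from compound 1 to compound 3 (0.42 log units; beyond the scatter) in this assay, so the choice of aromatic group shifts the number only modestly. Replacing cyclohexyl with 4-methylphenyl gives a 59-fold higher number from compound 2 to compound 3 (1.77 log units; beyond the scatter), which shows that both aromatic compounds here stand well above the cyclohexyl compound. Nothing available explains either shift. From the compounds shown here alone, it remains open how cyclopentyl, a longer chain such as n-butyl, or unsubstituted phenyl would read on this carbonyl carbon. Going by these compounds, it also remains open whether the modest shift follows the loss of the ethoxy group or the arrival of the methyl group.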